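The compounds below may be only part of what the source reports. "The series", "measured", "known", "first", "only" and "open" are said of these compounds alone.

Measured compounds:
compound 1 `COc1ccc(-c2nc(CN)sc2-c2ccc(OC)cc2)cc1` — > 100 nM
compound 2 `COc1ccc(-c2nc(C(=O)N3CCN(C(=O)NC(C)C)CC3)sc2-c2ccc(OC)cc2)cc1` — > 1000 nM

In a functional assay with Oryctolagus cuniculus as the target (on this read-out higher numbers stand for weaker inhibition and lower numbers for stronger inhibition), compound 1 gives > 100 nM, which is a limit of the assay and not a number. Compound 2 likewise gives > 1000 nM in this assay, again a limit rather than a measured value. Compound 1 therefore stands nowhere firm on the numbers shown: its own result is a limit, and the one further value shown is a limit as well, so no step between measured compounds can be stated, and the evidence amounts to the limit of > 100 nM in this assay, at which 1 of the 2 values shown sits, and (the limit of > 1000 nM in this assay, at which 1 of the 2 values shown sits).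

Compound 3 `COc1ccc(-c2nc(/C=C/C(=O)O)sc2-c2ccc(OC)cc2)cc1` shares the core of compound 1 and differs from it in one place: 2-carboxyethenyl in place of aminomethyl on an aromatic carbon. For the measured compounds named here, with both known values being limits, no measured step can anchor an expectation, and the change itself carries no evidence here of any effect. The step from compound 1 to compound 3 is expected to be a step that the limit leaves unreadable from compound 1 to compound 3, which is a guess at the direction rather than a reading of data. For compound 3 the estimated value in this assay is 3000 nM, with a range from 500 nM to 20000 nM, and it is expected that the assay may again report only a limit.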

Compound 3, half-maximal inhibitory concentration: > 100 nM
Compound 3 gave a limit, no number (the forecaster's own chance of this, stated with the estimate: 65%); the middle value is on the limit's open side.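

In this assay compound 3 gives only a limit, as compound 1 does, so no step can be read between compound 1 and compound 3. The compounds shown leave open how strongly any of them inhibits, and whether 2-carboxyethenyl in place of aminomethyl changes the read-out in either direction.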